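The compounds below may be only part of what the source reports. "The series", "measured", "known", "first", "only" and "open" are said of these compounds alone.

Compound 2 `CN(Cc1ccccc1)CC1CCN(CCCc2c[nH]c3ccc(-n4cnnc4)cc23)CC1` gives 0.95 nM in an assay on CHO cells for binding affinity to 5-hydroxytryptamine receptor 1D (Homo sapiens) (a lower number here means a stronger inhibitor, a higher number a weaker inhibitor), the lowest of the two numbers shown. Compound 1 `c1cc2[nH]cc(CCCN3CCCCC3)c2cc1-n1cnnc1` gives 24 nM, and the step of a 25-fold lower number from compound 1 to compound 2 (1.40 log units; beyond the scatter) is large. Compound 3 `CN(Cc1ccccc1)C1CCN(CCCc2c[nH]c3ccc(-n4cnnc4)cc23)CC1` differs from compound 2 by benzyl(methyl)amino in place of (benzyl(methyl)amino)methyl on a saturated ring carbon. Going by the values given here, the only measured step, from compound 1 to compound 2, shows that adding the benzyl(methyl)amino-bearing group brought a large gain, but no step tests keeping that group while changing how it is attached. For compound 3 I therefore expect a step of a 1.7-fold higher number from compound 2 to compound 3 (0.23 log units; within the scatter), most likely within the scatter, and estimate 1.6 nM with a range from 0.4 nM to 6.5 nM.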

Compound 3, half-maximal inhibitory concentration: 2.2 nM
The estimate for compound 3 lay 1.4-fold (0.14 log units) below the measured number, within the range that was stated.
By their numbers in this assay, from the lowest: compound 2; then compound 3; then compound 1.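

In this assay, setting benzyl(methyl)amino directly on the saturated ring carbon, in place of (benzyl(methyl)amino)methyl, brings a modest change (a 2.3-fold higher number from compound 2 to compound 3 (0.36 log units; beyond the scatter)). Against hydrogen at that carbon, the directly attached group still keeps a large gain (an 11-fold lower number from compound 1 to compound 3 (1.04 log units; beyond the scatter)), so the gain does not depend on the extra carbon link of compound 2. No measured evidence explains the difference between the two attachments.

On these data alone, it remains open whether the benzyl group or the amine nitrogen carries the gain. A dimethylamino group or a longer (benzyl(methyl)amino)ethyl chain at that carbon would test this further.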